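Moving the Thiophene Attachment Point on a Nucleoside Core

A few compounds are considered here, and "the series" means these few. Any claim that something is new, unique, unknown or untested is made for them only; others in the source may bear on it.

Measured compounds:
compound 1, `COc1ncnc2c1c(I)cn2[C@@H]1O[C@H](CO)[C@@H](O)[C@H]1O`, > 20000 nM in a functional assay on K562 cells (Homo sapiens), read by MTT assay, with a stated time of 72 h; on this read-out lower numbers stand for stronger inhibition and higher numbers for weaker inhibition
compound 2, `Cc1ncnc2c1c(-c1cccs1)cn2[C@@H]1O[C@H](CO)[C@@H](O)[C@H]1O`, > 20000 nM
compound 3, `COc1ncnc2c1c(-c1cccs1)cn2[C@@H]1O[C@H](CO)[C@@H](O)[C@H]1O`, 70 nM

Within the data shown here, compound 3 gives the only actual number in this assay. For compound 1 the value > 20000 nM is a limit of the assay, not a number. For compound 2 the value > 20000 nM is likewise a limit. Both limits sit at the limit of > 20000 nM in this assay, at which 2 of the 3 values shown sit. The two measured steps both run to compound 3 and are large: an at least 280-fold lower number from compound 1 to compound 3 (2.45 log units; beyond the scatter) and an at least 280-fold lower number from compound 2 to compound 3 (2.45 log units; beyond the scatter). They show that the group on this aromatic carbon, and the methoxy at its own position, each matter strongly.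

Compound 4, `COc1ncnc2c1c(-c1ccsc1)cn2[C@@H]1O[C@H](CO)[C@@H](O)[C@H]1O`, is not yet measured. It differs from compound 3 by thiophen-3-yl in place of thiophen-2-yl on an aromatic carbon. Among the measured compounds shown here, no measured step changes the attachment point of a thiophen-2-yl, so the size of this step cannot be read from the data; the shared place is known to be sensitive from the step of compound 1. A modest weakening is expected, a 2.9-fold higher number from compound 3 to compound 4 (0.46 log units; beyond the scatter). Compound 4 is therefore estimated at 200 nM, within 50 nM to 2000 nM.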

Compound 4, half-maximal inhibitory concentration: 90 nM
For compound 4 the middle estimate is 2.2-fold (0.35 log units) above the measured one; the range from low to high includes it.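

In this assay, the attachment point of the thiophene on this aromatic carbon turns out not to be decisive, with a change that stays within the scatter (a 1.3-fold higher number from compound 3 to compound 4 (0.11 log units; within the scatter)). The large gain over iodo is therefore not tied to thiophen-2-yl, since thiophen-3-yl also gives it (an at least 220-fold lower number from compound 1 to compound 4 (2.34 log units; beyond the scatter)). That step is open-ended, as compound 1 stands at a limit and not at a number: (the limit of > 20000 nM in this assay, at which 2 of the 4 values shown sit).

As far as these compounds go, whether a furan-2-yl or a phenyl on this aromatic carbon would keep such a value remains open. Also open, from the compounds shown here alone, is whether the methoxy matters as much alongside thiophen-3-yl as alongside thiophen-2-yl, and what an amine in its place would give.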